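This account rests on a few compounds, and the source may have more. Where it says the series, first, only, none or still open, it means among the compounds named here.

Three compounds have been measured in an assay on isolated protein for displacement of a labelled ligand from metabotropic glutamate receptor 5 (Homo sapiens), with a stated time of 60 min, tested at 1 uM; on this read-out lower numbers stand for less inhibition and higher numbers for more inhibition at the one concentration tested (going by the name of the read-out):
compound 1 `COc1ccc2ncc(S(=O)(=O)c3ccc(OC)c(Cl)c3)c(N3CCC(C)CC3)c2c1` gives 21%;
compound 2 `COc1ccc2ncc(S(=O)(=O)c3cccc(C#N)c3)c(N3CCC(C)CC3)c2c1` gives 90%;
compound 3 `Cc1ccc(S(=O)(=O)c2cnc3ccc(F)cc3c2N2CCC(C)CC2)cc1F` gives 86%.

On these numbers compound 3 lies within the usual scatter of compound 2 and well above compound 1. Compound 4 `COc1ccc2ncc(S(=O)(=O)c3ccc(C)c(F)c3)c(N3CCC(C)CC3)c2c1` has not yet been measured; it differs from compound 3 in a single place: methoxy in place of fluoro on an aromatic carbon. Among the measured compounds shown here, the one measured step, a number 69 percentage points higher from compound 1 to compound 2 (beyond the scatter), changes the ring on the sulfonyl sulfur and leaves the fused system of two rings untouched, so no measured step bears directly on the change that leads to compound 4. With nothing pointing to a shift, the expectation for compound 4 in this assay is a step of a number 6 percentage points lower from compound 3 to compound 4 (within the scatter), none beyond the scatter. Compound 4 is therefore estimated at 80%, with a range from 55% to 95%.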

Compound 4, a percentage reported as inhibition, at one concentration (the size of the read-out at that concentration, not a potency): 73%
The estimate for compound 4 lay 7 percentage points above the measured number; measured number inside the range.
By their numbers in this assay, from the lowest: compound 1; then compound 4; then compounds 3 and 2 (each within the scatter of the next).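

In this assay, the aromatic carbon of the fused system of two rings proves to be a position that responds: methoxy in place of fluoro gives a number 13 percentage points lower from compound 3 to compound 4 (beyond the scatter) as a modest step. With methoxy held there, the ring on the sulfonyl sulfur still counts, since 3-fluoro-4-methylphenyl gives a number 17 percentage points lower from compound 2 to compound 4 (beyond the scatter) against 3-cyanophenyl and a number 52 percentage points higher from compound 1 to compound 4 (beyond the scatter) against 3-chloro-4-methoxyphenyl. Nothing at hand explains these shifts. From the compounds shown here alone, whether the methoxy step holds with other rings on the sulfonyl sulfur stays open. So does what an amine or a hydroxy group on the same aromatic carbon would give.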